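Benzyl in Place of Butyl on a Weakly Cytotoxic Core

The compounds below may be only part of what the source reports. "The series", "measured", "known", "first", "only" and "open" are said of these compounds alone.

Of the compounds shown here, three sharing one core have been tested in a functional assay on HepG2 cells (Homo sapiens) for cytotoxicity, read by MTT assay, with a stated time of 72 h; a lower number here means a stronger inhibitor, a higher number a weaker inhibitor. Compound 1 `CCCCCN(CCCCC)c1nc2c(ncn2-c2ccccc2)c(=O)n1-c1ccc(Cl)cc1`, with a dipentylamino group, gives > 100000 nM, which is a limit of the assay and not a number. Compound 2 `O=c1c2ncn(-c3ccccc3)c2nc(N2CCCCC2)n1-c1ccc(Cl)cc1`, carrying a piperidin-1-yl group in the same place, likewise gives > 100000 nM, again a limit. Compound 3 `CCCCNc1nc2c(ncn2-c2ccccc2)c(=O)n1-c1ccc(Cl)cc1`, with a butylamino group, is the only one of the three for which a number is reported: in this assay compound 3 gives 77600 nM. The steps of an at least 1.2-fold lower number from compound 1 to compound 3 (0.11 log units; that floor lies within the scatter) and an at least 1.2-fold lower number from compound 2 to compound 3 (0.11 log units; that floor lies within the scatter) are therefore only floors, and the step that the two limits leave unreadable from compound 1 to compound 2 cannot be read at all, because two of the three values sit at the limit of > 100000 nM in this assay, at which 2 of the 3 values shown sit.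

Compound 4 `O=c1c2ncn(-c3ccccc3)c2nc(NCc2ccccc2)n1-c1ccc(Cl)cc1` differs from compound 3 by phenyl in place of propyl on a saturated chain carbon bound to a nitrogen on an aromatic ring. Within the data shown here, no measured step mirrors this change; the two steps that end at compound 3 are floors whose size lies within the scatter, so the expectation is a step no larger than the scatter, in no firm direction. Compound 4 is therefore estimated to give 80000 nM in this assay, within a range from 30000 nM to 200000 nM, meaning an expected step of a 1.0-fold higher number from compound 3 to compound 4 (0.01 log units; within the scatter) from compound 3 to compound 4.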

Compound 4, half-maximal inhibitory concentration: 62100 nM
For compound 4 the middle estimate is 1.3-fold (0.11 log units) above the measured one; the measured number falls inside the stated range.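

In this assay, among these compounds, the first step at this position that can be read as a number is a 1.2-fold lower number from compound 3 to compound 4 (0.10 log units; within the scatter), so a ring in place of an open chain on this saturated chain carbon leaves the reading indistinguishable from that of the butyl group. Butylamino and benzylamino are thus the two groups in this set that return numbers, while dipentylamino and piperidin-1-yl do not, a contrast that holds for these four compounds only. The other two new steps, an at least 1.6-fold lower number from compound 2 to compound 4 (0.20 log units; that floor lies within the scatter) and an at least 1.6-fold lower number from compound 1 to compound 4 (0.20 log units; that floor lies within the scatter), are floors and not measured sizes, because those comparisons start from a limit and not from a number: the limit of > 100000 nM in this assay, at which 2 of the 4 values shown sit.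

As far as these compounds go, the true size of those steps stays unknown, and the step between the two compounds at the limit cannot be read. Also open, from the compounds shown here alone, is whether a shorter chain such as ethyl, or a carboxylic acid or an amine on the phenyl ring of the benzylamino group, would move the number beyond the scatter of this assay.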